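The source may hold more compounds than are shown below. What is called first, only, known or untested is meant among the compounds shown, and "the series" means these compounds.

Compound 3 `COc1ccc(/C=C/C(=O)N2C[C@@H](NC(=O)c3ccc4no[n+]([O-])c4c3)C[C@H]2C(=O)NO)cc1OC` is measured in an assay for inhibition of matrix metalloproteinase-9 (Homo sapiens), read by fluorescence, with a stated time of 45 min (on this read-out higher numbers stand for weaker inhibition and lower numbers for stronger inhibition), where compound 3 gives 388 nM. Of the three numbers shown this is the largest, but compound 2 `O=C(N[C@H]1C[C@@H](C(=O)NO)N(S(=O)(=O)c2ccc(Oc3ccccc3)cc2)C1)c1cccc2no[n+]([O-])c12` gives 242 nM, a gap within the scatter, and only compound 1 `O=C(N[C@H]1C[C@@H](C(=O)NO)N(S(=O)(=O)c2ccc(Oc3ccccc3)cc2)C1)c1ccc2no[n+]([O-])c2c1`, which gives 162 nM, sits clearly lower. Compound 4 `COc1ccc(/C=C/C(=O)N2C[C@@H](NC(=O)c3cccc4no[n+]([O-])c34)C[C@H]2C(=O)NO)cc1OC` differs from compound 3 in one place: a group of 10 heavy atoms (6 carbon, 2 nitrogen, 2 oxygen; one five-membered aromatic ring with 3 hetero atoms, one six-membered aromatic ring of carbon only) in place of a group of 10 heavy atoms (6 carbon, 2 nitrogen, 2 oxygen; one five-membered aromatic ring with 3 hetero atoms, one six-membered aromatic ring of carbon only), on a carbonyl carbon. The same swap links the two earlier compounds, where a 1.5-fold higher number from compound 1 to compound 2 (0.17 log units; within the scatter). That step is the only one bearing on the present change, so in this assay the step expected from this change is estimated as a 1.5-fold higher number from compound 3 to compound 4 (0.17 log units; within the scatter), a drift to a higher number that stays within the scatter. Compound 4 is therefore estimated at 580 nM, within a range from 250 nM to 1300 nM.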

Compound 4, half-maximal inhibitory concentration: 524 nM
For compound 4 the middle estimate is 1.1-fold (0.04 log units) above the measured one; low and high end bracket the measured number.
By their numbers in this assay, from the lowest: compounds 1, 2, 3 and 4 (each within the scatter of the next, the first and the last beyond it).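

In this assay, the same swap of the group on the carbonyl carbon, now on a second core, gives a 1.4-fold higher number from compound 3 to compound 4 (0.13 log units; within the scatter). The two groups, made of the same atoms joined differently, therefore cannot be told apart on either core. The change has now been seen twice rather than once, and its size holds from one core to the other: the same change on two cores in this assay, a 1.5-fold higher number (0.17 log units; within the scatter) from compound 1 to compound 2 and a 1.4-fold higher number (0.13 log units; within the scatter) from compound 3 to compound 4, 1.1-fold (0.04 log units) apart, within the scatter of two such steps

Going by these compounds, what an amine or a carboxylic acid would give in this place on the carbonyl carbon remains open. So does whether the swap would read the same on any other core.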